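A smaller amide group after two limit values

The source may hold more compounds than are shown below. What is called first, only, known or untested is meant among the compounds shown, and "the series" means these compounds.

Compound 1 `CCn1c(C(=O)N(CCC#N)CCC#N)ccc1C(CC)(CC)c1ccc(OCCC(O)(CC)CC)c(C)c1`: > 50000 nM
Compound 2 `CCC(C)C(CO)NC(=O)c1ccc(C(CC)(CC)c2ccc(OCCC(O)(CC)CC)c(C)c2)n1CC`: > 50000 nM

In a functional assay on Caco-2 cells (Homo sapiens) for antiproliferative activity, read by MTT assay, with a stated time of 48 h (on this read-out higher numbers stand for weaker inhibition and lower numbers for stronger inhibition), compound 2 gives > 50000 nM, which is a limit and not a number. Compound 1 gives > 50000 nM, also a limit. This is the limit of > 50000 nM in this assay, at which 2 of the 2 values shown sit. Compound 3 `CCn1c(C(=O)N(C)CCO)ccc1C(CC)(CC)c1ccc(OCCC(O)(CC)CC)c(C)c1` changes one group: (2-hydroxyethyl)(methyl)amino in place of (1-(hydroxymethyl)-2-methylbutyl)amino on a carbonyl carbon. For the measured compounds named here, the only measured step is a step that the two limits leave unreadable from compound 1 to compound 2, so it offers no size to carry over. The expected result is therefore a number no higher from compound 2 to compound 3 (the limit leaves the size open), with the limit of compound 2 at > 50000 nM as the only anchor. Compound 3 is estimated at 50000 nM, within an expected range of 20000 nM to 120000 nM.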

Compound 3, half-maximal inhibitory concentration: 74 nM
Estimate against measurement, compound 3: 680-fold (2.83 log units) above; the whole stated range lies above it.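

In this assay, the group on this carbonyl carbon proves able to decide the result: (2-hydroxyethyl)(methyl)amino gives an at least 670-fold lower number from compound 2 to compound 3 (2.82 log units; beyond the scatter), and an at least 670-fold lower number from compound 1 to compound 3 (2.82 log units; beyond the scatter). For the compounds shown here, this is the first real number, so the position can now be read, whereas the step between the two earlier compounds cannot. The full size of both new steps stays unknown because each starts from a limit: the limit of > 50000 nM in this assay, at which 2 of the 3 values shown sit.

On these data alone, it remains open whether the hydroxyl or the methyl of the new group matters more. A dimethylamino group or a 2-hydroxyethylamino group on the same carbonyl carbon would help separate the two.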